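Amino Replaces Phenyl on a Flat Series

The compounds below may be only part of what the source reports. "The series", "measured", "known", "first", "only" and "open" are said of these compounds alone.

Measured so far in a functional assay on COLO 320 cells (Homo sapiens) for antiproliferative activity, read by WST assay, with a stated time of 72 h; a higher number here means a weaker inhibitor, a lower number a stronger inhibitor:
compound 1, `Cc1noc(-c2cc3ccccc3[nH]2)n1`, gives 11800 nM
compound 2, `c1ccc(-c2noc(-c3cc4ccccc4[nH]3)n2)cc1`, gives 12000 nM
compound 3, `O=[N+]([O-])c1ccc2[nH]c(-c3nc(-c4ccccc4)no3)cc2c1`, gives 12500 nM

Compound 2 stands second highest of the three numbers in this assay, but all three lie within the scatter of one another, so no order among them can be read. The step to compound 4, `Nc1noc(-c2cc3ccccc3[nH]2)n1`, is amino in place of phenyl on an aromatic carbon. For the measured compounds named here, two measured steps bear on this position or its surroundings. The step of a 1.0-fold higher number from compound 1 to compound 2 (0.01 log units; within the scatter) changed the group on the same aromatic carbon and left the number where it was. The step of a 1.0-fold higher number from compound 2 to compound 3 (0.02 log units; within the scatter) altered a distant part of the core and likewise showed nothing beyond the scatter. Going by the values given here, since the one change so far at this very carbon, from methyl to phenyl, produced no shift, the smaller amino group is expected to behave in the same way, with the step of no change at the digits printed from compound 2 to compound 4 (within the scatter) expected to fall within the scatter. Compound 4 is therefore estimated at 12000 nM in this assay, with a range from 5000 nM to 30000 nM.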

Compound 4, half-maximal inhibitory concentration: 27700 nM
Compound 4: the middle estimate sits 2.3-fold (0.36 log units) below what was measured; the range from low to high includes it.
By their numbers in this assay, from the lowest: compounds 1, 2 and 3 (each within the scatter of the next); then compound 4.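

In this assay, amino in place of phenyl gives a 2.3-fold higher number from compound 2 to compound 4 (0.36 log units; beyond the scatter), and amino in place of methyl gives a 2.3-fold higher number from compound 1 to compound 4 (0.37 log units; beyond the scatter). This aromatic carbon, between two ring nitrogen atoms, therefore responds to a change of group, modestly but beyond the scatter, which the step from methyl to phenyl had not shown. Amino is the only one of the three groups here with a hydrogen-bond donor and acceptor, but one compound sets no rule, and nothing measured here gives a reason for the shift.

The compounds shown leave open whether a dimethylamino group or a hydroxyl at this carbon would move the number as amino does. They also leave open whether amino would have the same effect on the nitro-bearing core of compound 3.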